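This account rests on a few compounds, and the source may have more. Where it says the series, first, only, none or still open, it means among the compounds named here.

Of the compounds shown here, three built on one shared core have been tested in a functional assay on cells (T-cell, Mus musculus, strain BALB/c) for inhibition, read by MTT assay, with a stated time of 72 h; on this read-out lower numbers stand for stronger inhibition and higher numbers for weaker inhibition. Compound 1 `COC(=O)c1cc(O)ccc1OC(=O)COc1cc(O)c2c(=O)cc(-c3ccccc3)oc2c1` gives 29500 nM in this assay. Compound 2 `COC(=O)c1c(C)cccc1OC(=O)COc1cc(O)c2c(=O)cc(-c3ccccc3)oc2c1` gives 37200 nM. Compound 3 `COC(=O)c1ccc(Br)cc1OC(=O)COc1cc(O)c2c(=O)cc(-c3ccccc3)oc2c1` gives 17600 nM, the lowest of the three numbers; compound 1 lies nearest to it and compound 2 furthest, as the steps show: a 1.7-fold lower number from compound 1 to compound 3 (0.22 log units; within the scatter) and a 2.1-fold lower number from compound 2 to compound 3 (0.33 log units; beyond the scatter). The step of a 1.3-fold higher number from compound 1 to compound 2 (0.10 log units; within the scatter) also belongs to this set.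

Compound 4 `COC(=O)c1cc(Cl)ccc1OC(=O)COc1cc(O)c2c(=O)cc(-c3ccccc3)oc2c1` differs from compound 3 in one place:
a group of 11 heavy atoms (8 carbon, 2 oxygen, 1 chlorine; one six-membered aromatic ring of carbon only) in place of a group of 11 heavy atoms (8 carbon, 2 oxygen, 1 bromine; one six-membered aromatic ring of carbon only), on an oxygen next to a carbonyl group

All three measured steps concern exchanges of the same group on the oxygen next to the carbonyl, and each moved the number only a little, one of them just beyond the scatter. The exchange of bromine for chlorine in the 4-chloro-2-(methoxycarbonyl)phenyl group is therefore expected to produce no step beyond the scatter in this assay, with no direction favoured. On that basis compound 4 is expected to give 20000 nM, within a range from 10000 nM to 40000 nM, which means an expected step of a 1.1-fold higher number from compound 3 to compound 4 (0.06 log units; within the scatter).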

Compound 4, half-maximal inhibitory concentration: 3740 nM
For compound 4 the middle estimate is 5.3-fold (0.73 log units) above the measured one; the measured number lies below the stated range.
By their numbers in this assay, from the lowest: compound 4; then compounds 3, 1 and 2 (each within the scatter of the next, the first and the last beyond it).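

The group on the oxygen next to a carbonyl group proves able to move the number well beyond the scatter in this assay, whereas the earlier exchanges there stayed small. The 4-chloro-2-(methoxycarbonyl)phenyl group in place of the bromine-bearing group gives a 4.7-fold lower number from compound 3 to compound 4 (0.67 log units; beyond the scatter), and against the methyl-bearing group it gives a 9.9-fold lower number from compound 2 to compound 4 (1.00 log units; beyond the scatter). Chloro in place of hydroxy on an aromatic carbon gives a 7.9-fold lower number from compound 1 to compound 4 (0.90 log units; beyond the scatter), so compound 4 now stands beyond the scatter from all three others, with the lowest number of the set. No supporting measurement bears on why this group differs from the others.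

The compounds shown leave open whether 4-bromo-2-(methoxycarbonyl)phenyl or 4-fluoro-2-(methoxycarbonyl)phenyl would match compound 4. They also leave open what an amine or a methyl group would give in place of that chloro.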